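This account rests on a few compounds, and the source may have more. Where it says the series, first, only, none or still open, it means among the compounds named here.

Series notes. Compound 1 `COc1ccc(Cl)cc1C(=O)NCC1CCN(S(=O)(=O)NC(=O)NC[C@@H]2C[C@@H]3C=C[C@@H]2C3)CC1` and compound 2 `COc1ccc(Cl)cc1C(=O)NCCC1CCN(S(=O)(=O)NC(=O)NC[C@@H]2C[C@@H]3C=C[C@@H]2C3)CC1` share one core and have both been tested in a functional assay on the whole organism (blood) with Rattus norvegicus as the target, with stated times of 24 h and 1 h, at a dose of 5 mg/kg by the intraperitoneal route; a higher number here means a stronger effect of the compound at the dose given, a lower number a weaker effect. In this assay compound 1 gives 15%, and compound 2 gives 37%, the higher of the two numbers and beyond the scatter from compound 1. Compound 3 `COc1ccc(NC(=O)NS(=O)(=O)N2CCC(CCNC(=O)c3cc(Cl)ccc3OC)CC2)cc1` has not yet been measured. It differs from compound 2 in one place: a group of 8 heavy atoms (7 carbon, 1 oxygen; one six-membered aromatic ring of carbon only) in place of a group of 8 heavy atoms (8 carbon; 2 five-membered non-aromatic rings of carbon only), on an amide-type nitrogen. Within the data shown here, no measured pair shows this change, so its effect is unknown. A downward step of moderate size, a number 7 percentage points lower from compound 2 to compound 3 (within the scatter), is expected, with wide uncertainty. Compound 3 is estimated at 30%, in a range from 10% to 55%.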

Compound 3, a percentage reported as activity, at one dose (the size of the read-out at that dose, not a potency): 27%
For compound 3 the middle estimate is 3 percentage points above the measured one; measured number inside the range.
By their numbers in this assay, from the lowest: compound 1; then compounds 3 and 2 (each within the scatter of the next).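

On the amide-type nitrogen whose other neighbour is the carbonyl carbon, 4-methoxyphenyl in place of the group with two five-membered non-aromatic rings gives a number 10 percentage points lower from compound 2 to compound 3 (within the scatter) in this assay. This position therefore tolerates a six-membered aromatic ring of carbon only with no step beyond the scatter, so the group with two five-membered non-aromatic rings is not required here for the read-out of compound 2.

Going by these compounds, how a plain phenyl, a cyclohexyl or a carboxylic acid on this nitrogen would read remains open. Nothing available explains the result for this pair.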